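The source may hold more compounds than are shown below. What is called first, only, known or untested is meant among the compounds shown, and "the series" means these compounds.

Values measured in a physicochemical assay for lipophilicity, read by HPLC, using the shake flask method (on this read-out higher numbers stand for higher lipophilicity and lower numbers for lower lipophilicity), are as follows.

- Compound 1 `CCCCCN(Cc1ccc(Cl)nc1)/C(C)=N/C#N` gives 2.37
- Compound 2 `CCC/C(=N\C#N)N(C)Cc1ccc(Cl)nc1` gives 1.55
- Compound 3 `C/C(=N\C#N)N(Cc1ccc(Cl)nc1)C(C)C` gives 1.46

Compound 2 cannot be told apart from compound 3 on these numbers, and it lies clearly under compound 1. Compound 4 `CCCCC/C(=N\C#N)N(C)Cc1ccc(Cl)nc1` has not yet been measured. It differs from compound 2 by one change, (ethyl in place of hydrogen on a saturated chain carbon, three bonds along the chain from a carbon with a double bond to nitrogen), which also reads as propyl to pentyl. Going by the values given here, one measured step bears on this: a number 0.91 log units lower from compound 1 to compound 3 (beyond the scatter), with isopropyl in place of pentyl on an amine nitrogen. That modest step lies at another place, so it is only a guide. A rise of similar size, beyond the scatter, is therefore expected in this assay for this change. The expected step is a number 0.85 log units higher from compound 2 to compound 4 (beyond the scatter) in size. The estimate for compound 4 is 2.4 with an expected range of 2.05 to 2.75.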

Compound 4, partition coefficient: 2.3
Beside the measured number, compound 4's estimate is 0.10 log units above it; low and high end bracket the measured number.
By their numbers in this assay, from the lowest: compounds 3 and 2 (each within the scatter of the next); then compounds 4 and 1 (each within the scatter of the next).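

In this assay, going by these compounds alone, the propyl to pentyl change gives a number 0.75 log units higher from compound 2 to compound 4 (beyond the scatter) and so shows that the read-out responds at this position itself, where the earlier compounds offered only a step on an amine nitrogen. This modest step is the only one shown at this place. Nothing given here explains its size.

From the compounds shown here alone, whether a longer chain, or an amine or a carboxylic acid in place of the ethyl, would move the number further stays open. So does whether the step would hold with pentyl rather than methyl on the amine nitrogen.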